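Compound 3 trades pyrrolidin-1-yl for amino

This account rests on a few compounds, and the source may have more. Where it says the series, first, only, none or still open, it means among the compounds named here.

Measured in a toxicity assay on HepG2 cells (Homo sapiens) for inhibition, read by resazurin assay, with a stated time of 24 h; a lower number here means that less compound is tolerated, a higher number that more compound is tolerated
- Compound 1 `Cn1c([N+](=O)[O-])cnc1C(=O)NCc1ccc(F)cc1` gives > 100000 nM
- Compound 2 `Cn1c([N+](=O)[O-])cnc1C(=O)N1CCCC1` gives > 100000 nM
- Compound 3 `O=C(c1ncc([N+](=O)[O-])[nH]1)N1CCCC1` gives > 100000 nM

Compound 3 stands at > 100000 nM, which is a limit of the assay and not a number. It shares that position with the other two compounds, as the data show (the limit of > 100000 nM in this assay, at which 3 of the 3 values shown sit).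

The next structure, compound 4 `NC(=O)c1ncc([N+](=O)[O-])[nH]1`, has amino in place of pyrrolidin-1-yl on a carbonyl carbon.

Going by the values given here, the one measured step that bears on this series is a step that the two limits leave unreadable from compound 2 to compound 3. It concerns a hydrogen in place of a methyl on an aromatic nitrogen, a different change, and it offers no size to carry over. No step of readable size exists among these compounds.

Since compound 3 gives > 100000 nM, a limit, no step beyond the scatter is expected in this assay in either direction. The step expected is a step that the limit leaves unreadable from compound 3 to compound 4. The assay may well report only a limit again. For compound 4 the estimate is 150000 nM, with an expected range from 60000 nM to 400000 nM.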

Compound 4, half-maximal cytotoxic concentration: > 100000 nM
Compound 4: only a limit was reported; the forecaster's own chance of this, stated with the estimate: 85%; the middle value does not contradict the limit.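

No size can be read for the step from compound 3 to compound 4, because both values are limits of the assay and not numbers: the limit of > 100000 nM in this assay, at which 4 of the 4 values shown sit.

The compounds shown leave open where each half-maximal cytotoxic concentration truly lies, and whether any of these structural changes shifts it at all.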